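Chloro for trifluoromethyl on the aryl ether ring

The source may report more compounds than this note shows. Statements on the series, on what has been measured and on what is new or still open speak of the compounds shown alone.

Working notes on a small set of thiazolidinedione aryl ethers tested in a functional assay for agonist activity at Free fatty acid receptor 1 (Homo sapiens), read by FLIPR, in the presence of a further agent that is not named here; a lower number here means that less compound is needed, a higher number that more compound is needed for the effect. Compound 1 `O=C1NC(=O)C(Cc2ccc(Oc3ccc(Cl)cn3)cc2)S1` gives 1870 nM in this assay. Compound 2 `O=C1NC(=O)C(Cc2ccc(Oc3ncc(Cl)cc3Cl)cc2Cl)S1` gives 63 nM. Compound 3 `O=C1NC(=O)C(Cc2ccc(Oc3ncc(C(F)(F)F)cc3Cl)cc2)S1` gives 69 nM. On these three numbers compound 3 sits alongside compound 2, the gap between the two lying within the usual scatter, so no order between them can be stated; compound 1 stands apart with a higher number, and that gap is beyond the scatter.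

Compound 4 `O=C1NC(=O)C(Cc2ccc(Oc3ncc(Cl)cc3Cl)cc2)S1` has not yet been measured in this assay. It differs from compound 3 in one place: chloro in place of trifluoromethyl on an aromatic carbon. Going by the values given here, no single-change pair among the measured compounds matches this swap, so no measured step can be carried over directly. The trifluoromethyl and the chloro both sit on the same carbon of the six-membered aromatic ring with one nitrogen, and the remainder of the structure is unchanged.

Given that compound 3 gives 69 nM and compound 2 gives 63 nM, compound 4 is expected to land in the same region, with a step from compound 3 to compound 4 of about a 1.3-fold higher number from compound 3 to compound 4 (0.12 log units; within the scatter), most likely none beyond the scatter or a modest move to a higher number. The estimate for compound 4 is 90 nM, with a range from 35 nM to 250 nM.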

Compound 4, half-maximal effective concentration: 90 nM
Compound 4: middle estimate and measured number agree at the digits printed, within the range that was stated.
By their numbers in this assay, from the lowest: compounds 2, 3 and 4 (each within the scatter of the next); then compound 1.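

In this assay, the step of a 1.3-fold higher number from compound 3 to compound 4 (0.12 log units; within the scatter) replaces trifluoromethyl with chloro on an aromatic carbon two atoms from the ring nitrogen, so the two groups cannot be told apart at this position, although one has 4 heavy atoms and the other 1. Going by these compounds alone, the step of a 1.4-fold higher number from compound 2 to compound 4 (0.15 log units; within the scatter), hydrogen in place of chloro on an aromatic carbon, is also within the scatter, while the step of a 21-fold lower number from compound 1 to compound 4 (1.32 log units; beyond the scatter), chloro in place of hydrogen on an aromatic carbon, is large and the only single-place step here that lies beyond it. The compounds therefore separate at the chloro gained from compound 1 to compound 4, not at the swap from trifluoromethyl to chloro, and no measurement offered here explains either result.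

Going by these compounds, whether this position also tolerates a nitrile, a methoxy group or an amine remains open, since only trifluoromethyl and chloro are compared there. On these data alone, it is also open whether the large step seen with chloro in place of hydrogen would recur with trifluoromethyl or a longer chain on the same carbon.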